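The source may report more compounds than this note shows. Statements on the series, on what has been measured and on what is new or still open speak of the compounds shown alone.

This small set shares one core and is varied at two places: the group on the amide-type nitrogen of the five-membered ring, and the substituted phenyl on the side-chain amide. Compound 1 has the structure `CCCCCN1C(=O)C/C(=C\c2cccc(C(=O)Nc3ccc(C)cc3)c2)C1=O`. In an ADME assay on SW480 cells (Homo sapiens) for cytotoxicity, read by MTT assay, with a stated time of 72 h (on this read-out higher numbers stand for weaker inhibition and lower numbers for stronger inhibition), compound 1 gives only a limit, > 100000 nM, so no number is reported for it. Compound 2 has the structure `CCCCCN1C(=O)C/C(=C\c2cccc(C(=O)Nc3cccc(CC)c3)c2)C1=O`, and in this assay compound 2 gives 83300 nM. The step of an at least 1.2-fold lower number from compound 1 to compound 2 (0.07 log units; that floor lies within the scatter) rests on a floor set by the limit of > 100000 nM in this assay, at which 1 of the 3 values shown sits. Compound 3 has the structure `COc1ccc(NC(=O)c2cccc(/C=C3\CC(=O)N(c4ccc(C)cc4)C3=O)c2)cc1`; in this assay compound 3 gives 93000 nM, the higher of the two numbers shown, though its gap to compound 2 lies within the scatter.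

Compound 4 has the structure `CCCCCN1C(=O)C/C(=C\c2cccc(C(=O)Nc3ccc(OC)cc3)c2)C1=O`. The change from compound 3 is pentyl in place of 4-methylphenyl on an amide-type nitrogen in a ring. Among the measured compounds shown here, no measured step touches this position, but compounds 1 and 2 already carry the pentyl and sit in the same weak region as compound 3. Compound 4 is therefore expected to give a step of a 1.0-fold lower number from compound 3 to compound 4 (0.01 log units; within the scatter) of no size beyond the scatter. For compound 4 the estimate in this assay is 90000 nM, expected to lie between 40000 nM and 200000 nM.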

Compound 4, half-maximal inhibitory concentration: > 100000 nM
Compound 4 gave a limit, no number; the forecaster's own chance of this, stated with the estimate: 40%; at least 1.1-fold (0.04 log units) between middle value and limit.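

In this assay compound 4 gives > 100000 nM, which is a limit and not a number. Among the compounds shown here, this gives the first direct comparison at the amide-type nitrogen in the ring, and it shows an at least 1.0-fold higher number from compound 3 to compound 4 (0.03 log units; that floor lies within the scatter), while the change on the side-chain amide shows an at least 1.2-fold higher number from compound 2 to compound 4 (0.07 log units; that floor lies within the scatter); the step between the two compounds that both end in a limit cannot be read. Neither readable step shows a change beyond the scatter, so exchanging 4-methylphenyl for pentyl on this nitrogen brings no detectable gain in this small set, and how large any loss might be stays hidden, as the readings here are capped by one limit: the limit of > 100000 nM in this assay, at which 2 of the 4 values shown sit.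

Still open, as far as these compounds go, is whether a longer chain, or a chain ending in an amine, on this nitrogen would give a number clearly lower than those seen here. A carboxylic acid on the phenyl of the side-chain amide is equally untested among the compounds shown, so the reach of either position beyond this weak region remains unknown.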